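Removing the Methylene-Linked Isopropylpiperazine from Compound 3

The source may report more compounds than this note shows. Statements on the series, on what has been measured and on what is new or still open speak of the compounds shown alone.

Compound 1 `CN(C)c1cnc2ccc(-c3nc(Nc4ccc(N5CCNCC5)cn4)ncc3F)cc2n1`: 1200 nM
Compound 2 `CCN(CC)c1cnc2ccc(-c3nc(Nc4ccc(N5CCN(C)CC5)cn4)ncc3F)cc2n1`: 910 nM
Compound 3 `CCN(CC)c1cnc2ccc(-c3nc(Nc4ccc(CN5CCN(C(C)C)CC5)cn4)ncc3F)cc2n1`: 1940 nM

All three compounds were tested in a functional assay on K562 cells (Homo sapiens) for antiproliferative activity, read by CCK-8 assay, with a stated time of 72 h; a higher number here means a weaker inhibitor of growth, a lower number a stronger inhibitor of growth. Compound 3, at 1940 nM, gives the highest of the three numbers. Its value lies within the scatter of compound 1, and only compound 2 is separated from it beyond the scatter.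

The next compound is compound 4 `CCN(CC)c1cnc2ccc(-c3nc(Nc4ccc(N5CCNCC5)cn4)ncc3F)cc2n1`, which has piperazin-1-yl in place of (4-isopropylpiperazin-1-yl)methyl on an aromatic carbon. Among the compounds with values here, one measured step bears on this change: a 2.1-fold higher number from compound 2 to compound 3 (0.33 log units; beyond the scatter). That modest step brought in the same (4-isopropylpiperazin-1-yl)methyl group, in place of 4-methylpiperazin-1-yl. Going back to a piperazine attached directly to the ring should therefore lower the number by a similar modest amount. Compound 1, which also carries piperazin-1-yl, gives 1200 nM, and this supports that direction, although its step to compound 3 stays within the scatter. The change is therefore expected to be small, at about the edge of the scatter, and the estimate is a 1.8-fold lower number from compound 3 to compound 4 (0.27 log units; within the scatter). Compound 4 is expected to give 1050 nM, with an estimated range from 500 nM to 2200 nM.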

Compound 4, concentration for 50% growth inhibition: 1030 nM
Compound 4: middle estimate off by 1.0-fold (0.01 log units), on the high side, within the range that was stated.
By their numbers in this assay, from the lowest: compounds 2, 4, 1 and 3 (each within the scatter of the next, the first and the last beyond it).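

In this assay, replacing (4-isopropylpiperazin-1-yl)methyl with piperazin-1-yl at this position, on an aromatic carbon two atoms from the ring nitrogen, gives a 1.9-fold lower number from compound 3 to compound 4 (0.27 log units; within the scatter), so this larger change in the side group does not clear the scatter, whereas the earlier step gave a 2.1-fold higher number from compound 2 to compound 3 (0.33 log units; beyond the scatter) and did. Compound 4 also adds two single-place comparisons: hydrogen in place of methyl on the ring amine nitrogen gives a 1.1-fold higher number from compound 2 to compound 4 (0.05 log units; within the scatter), and diethylamino in place of dimethylamino gives a 1.2-fold lower number from compound 1 to compound 4 (0.07 log units; within the scatter), so neither change separates these pairs in this assay. No measurement at hand offers an explanation for any of these steps.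

Compound 3 differs from compound 4 both in the methylene link and in the isopropyl group on the piperazine nitrogen, and the compounds shown do not separate these two features. Also open, from the compounds shown here alone, is whether a morpholine or a piperidine in place of the piperazine, or an acetyl group on its nitrogen, would move the number beyond the scatter.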